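Hydroxyl in Place of Vinyl on a Nucleoside Disulfide

The source may hold more compounds than are shown below. What is called first, only, known or untested is meant among the compounds shown, and "the series" means these compounds.

Compounds 1, 2 and 3 share one core and differ only in the group carried on the outer sulfur of a disulfide. Compound 1 `Cc1cn([C@H]2C[C@H](SSC(Cl)(Cl)Cl)[C@@H](CO)O2)c(=O)[nH]c1=O` gives 55000 nM in a functional assay on MOLT-4 cells (Homo sapiens) for cytotoxicity; on this read-out higher numbers stand for weaker inhibition and lower numbers for stronger inhibition. Compound 2 `C=CCSS[C@H]1C[C@H](n2cc(C)c(=O)[nH]c2=O)O[C@@H]1CO` gives 34000 nM in this assay, and compound 3 `CCCCCCCCSS[C@H]1C[C@H](n2cc(C)c(=O)[nH]c2=O)O[C@@H]1CO` gives 26000 nM in this assay. Among these three, compound 2 stands with the second highest number; its nearest neighbour is compound 3, and the step of a 1.3-fold lower number from compound 2 to compound 3 (0.12 log units; within the scatter) lies within the scatter, as does a 1.6-fold lower number from compound 1 to compound 2 (0.21 log units; within the scatter). Only a 2.1-fold lower number from compound 1 to compound 3 (0.33 log units; beyond the scatter) edges past it.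

Compound 4 `Cc1cn([C@H]2C[C@H](SSCCO)[C@@H](CO)O2)c(=O)[nH]c1=O` has not been measured. It differs from compound 2 by hydroxymethyl in place of vinyl on a saturated chain carbon bound to a sulfur. The measured steps that bear on this change are the exchanges at the same place, a 1.3-fold lower number from compound 2 to compound 3 (0.12 log units; within the scatter) and a 1.6-fold lower number from compound 1 to compound 2 (0.21 log units; within the scatter), both small. Among the compounds with values here, no measured step introduces a hydroxyl, so nothing beyond the scatter is expected in this assay. For compound 4 the estimate is 35000 nM, with a range from 15000 nM to 80000 nM, which means an expected step of a 1.0-fold higher number from compound 2 to compound 4 (0.01 log units; within the scatter).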

Compound 4, half-maximal inhibitory concentration: 128000 nM
Compound 4: the middle estimate sits 3.7-fold (0.56 log units) below what was measured, and the stated range ends below it.
By their numbers in this assay, from the lowest: compounds 3, 2 and 1 (each within the scatter of the next, the first and the last beyond it); then compound 4.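

Among compounds 1, 2 and 3, exchanging the group on the outer sulfur barely moved the number in this assay, yet a hydroxyl at the end of this short chain does move it (a 3.8-fold higher number from compound 2 to compound 4 (0.58 log units; beyond the scatter)). The effect also holds against the other two groups (a 4.9-fold higher number from compound 3 to compound 4 (0.69 log units; beyond the scatter); a 2.3-fold higher number from compound 1 to compound 4 (0.37 log units; beyond the scatter)), which makes compound 4 the weakest of the four, so this position is not indifferent to what it carries. Nothing available here explains the shift.

On these data alone, it remains open whether the hydroxyl itself matters or whether an amine or a carboxylic acid at the end of the same chain would raise the number as well. Also open, as far as these compounds go, is whether a hydroxyl at the end of a longer chain, such as an octyl chain, would have the same effect.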